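This account rests on a few compounds, and the source may have more. Where it says the series, first, only, none or still open, it means among the compounds named here.

Compound 1, `COc1ccc(CCCCCCCCOc2ccc(CSc3cccc(NS(=O)(=O)C(F)(F)F)c3)nc2/C=C/C(=O)O)cc1`, gives 284 nM in an assay for binding affinity to leukotriene B4 receptor 1 (Homo sapiens); a higher number here means a weaker inhibitor, a lower number a stronger inhibitor.
Compound 2, `COc1ccc(CCCCCCCCOc2ccc(C[S+]([O-])c3cccc(N)c3)nc2/C=C/C(=O)O)cc1`, gives 4.7 nM in this assay.
Compound 3, `COc1ccc(CCCCCCCCOc2ccc(CSc3cccc(OC)c3)nc2/C=C/C(=O)O)cc1`, gives 192 nM in this assay.

Compound 3 sits second highest of the three numbers: compound 1 is its nearest neighbour, a step within the scatter, while compound 2 lies far below it, with a 41-fold higher number from compound 2 to compound 3 (1.61 log units; beyond the scatter) marking that gap.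

Compound 4 is `COc1ccc(CCCCCCCCOc2ccc(CSc3ccccc3)nc2/C=C/C(=O)O)cc1`. It differs from compound 3 by hydrogen in place of methoxy on an aromatic carbon, at a position described as meta to a large group.

The step that bears most directly on this change is a 1.5-fold lower number from compound 1 to compound 3 (0.17 log units; within the scatter), where one substituent at this same aromatic carbon replaced another and the number hardly moved. The large step from compound 2 to compound 3 involved two changes at once and does not isolate this position. Removing the methoxy altogether is therefore expected to give at most a small step, so compound 4 is estimated at 240 nM, within 100 nM to 600 nM, a step of a 1.3-fold higher number from compound 3 to compound 4 (0.10 log units; within the scatter) that is expected to lie within the scatter.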

Compound 4, inhibition constant: 74 nM
Estimate against measurement, compound 4: 3.2-fold (0.51 log units) above; measured number below the stated range.
By their numbers in this assay, from the lowest: compound 2; then compound 4; then compounds 3 and 1 (each within the scatter of the next).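

In this assay, compound 4 shows that this aromatic carbon does respond to its substituent: removing methoxy gives a 2.6-fold lower number from compound 3 to compound 4 (0.41 log units; beyond the scatter) and removing ((trifluoromethyl)sulfonyl)amino gives a 3.8-fold lower number from compound 1 to compound 4 (0.58 log units; beyond the scatter) with both steps beyond the scatter and in the same direction, even though those two groups had stood within the scatter of each other. Among these three compounds, hydrogen therefore gives the lowest number, yet a 16-fold higher number from compound 2 to compound 4 (1.20 log units; beyond the scatter) remains large, and that step exchanges a whole group of heavy atoms rather than isolating this position. No measurement shown accounts for either gain on removal.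

The compounds shown leave open how the gap to compound 2 divides between its amino group and the oxygen on its sulfur. An amino group at this carbon, with the sulfur kept as in compound 4, would separate the two.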